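This account rests on a few compounds, and the source may have more. Where it says the series, first, only, none or still open, it means among the compounds named here.

Measured compounds:
compound 1, `COCC1CCN(c2c(S(=O)(=O)c3ccc(F)cc3)cnc3cc(F)ccc23)CC1`: 76.1%
compound 2, `COCC1CCN(c2c(S(=O)(=O)c3cc(F)cc(F)c3)cnc3cc(F)ccc23)CC1`: 83%

Compound 1 and compound 2 were both tested in an assay on isolated protein for displacement of a labelled ligand from metabotropic glutamate receptor 5 (Homo sapiens), with a stated time of 60 min, tested at 1 uM; on this read-out lower numbers stand for less inhibition and higher numbers for more inhibition at the one concentration tested (going by the name of the read-out). The two numbers lie within the usual scatter of each other: the step of a number 6.9 percentage points higher from compound 1 to compound 2 (within the scatter) is too small to be read as a real difference, so on the numbers shown compound 1 stands level with its one neighbour. Compound 3, `CC1CCN(c2c(S(=O)(=O)c3ccc(F)cc3)cnc3cc(F)ccc23)CC1`, has not yet been tested. It differs from compound 1 in one place: hydrogen in place of methoxy on a saturated chain carbon bound to a saturated ring carbon. For the measured compounds named here, no measured step touches this part of the molecule; the only measured step, from compound 1 to compound 2, changes the fluorine pattern on the sulfonyl aryl ring and says nothing about the methoxy. With no guide from the data, the expectation for compound 3 is a step of about a number 4.1 percentage points lower from compound 1 to compound 3 (within the scatter), which is no change beyond the scatter. Compound 3 is therefore estimated at 72%, with a range from 50% to 88%.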

Compound 3, a percentage reported as inhibition, at one concentration (the size of the read-out at that concentration, not a potency): 74.5%
The estimate for compound 3 lay 2.5 percentage points below the measured number; measured number inside the range.
By their numbers in this assay, from the lowest: compounds 3, 1 and 2 (each within the scatter of the next).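

In this assay, putting hydrogen in place of methoxy on a saturated chain carbon bound to a saturated ring carbon gives a number 1.6 percentage points lower from compound 1 to compound 3 (within the scatter), so the methoxy group is not required to keep the reading in this range. For the compounds shown here, this is the first look at this part of the molecule, and it shows that 4-methylpiperidin-1-yl serves as well as 4-(methoxymethyl)piperidin-1-yl in this single-concentration test, which is not a measure of potency. No supporting data are available to explain this result.

From the compounds shown here alone, it remains open whether a group of another kind at this place, such as an amine, a carboxylic acid or a longer chain, would give a similar reading. Going by these compounds, it is also open whether 4-methylpiperidin-1-yl would read the same alongside the 3,5-difluorophenyl group of compound 2.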